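Series notes: chain amine exchange on compound 1

The source may hold more compounds than are shown below. What is called first, only, known or untested is meant among the compounds shown, and "the series" means these compounds.

Measured compounds in this set:
compound 1 `COc1cc2c(Oc3ccc(NC(=O)c4nn(-c5ccccc5F)c(=O)c5ccccc45)cc3F)ccnc2cc1OCCCN1CCN(C)CC1` — 210 nM
compound 2 `COc1cc2c(Oc3ccc(NC(=O)c4nn(-c5ccccc5Br)c(=O)c5ccccc45)cc3F)ccnc2cc1OCCCN1CCN(C)CC1` — 400 nM
compound 3 `COc1cc2c(Oc3ccc(NC(=O)c4nn(-c5ccc([N+](=O)[O-])cc5)c(=O)c5ccccc45)cc3F)ccnc2cc1OCCCN1CCN(C)CC1` — 1320 nM

In a functional assay on MKN-45 cells (Homo sapiens) for cytotoxicity, read by MTT assay, with a stated time of 72 h (a higher number here means a weaker inhibitor, a lower number a stronger inhibitor), compound 1 gives the lowest number of the three. The step of a 1.9-fold higher number from compound 1 to compound 2 (0.28 log units; within the scatter) stays within the scatter, so compounds 1 and 2 are not separated by these data. The steps of a 6.3-fold higher number from compound 1 to compound 3 (0.80 log units; beyond the scatter) and a 3.3-fold higher number from compound 2 to compound 3 (0.52 log units; beyond the scatter) lie beyond the scatter, and both come from a change of the substituent on an aromatic nitrogen of the shared core.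

Compound 4 `COc1cc2c(Oc3ccc(NC(=O)c4nn(-c5ccccc5F)c(=O)c5ccccc45)cc3F)ccnc2cc1OCCCN1CCC(C)CC1` is not yet measured. It differs from compound 1 in 4-methylpiperidin-1-yl in place of 4-methylpiperazin-1-yl on a saturated chain carbon, three bonds along the chain from an oxygen on an aromatic ring. Going by the values given here, none of the three measured steps touches this chain; each of them alters only the group on the aromatic nitrogen, so no measured step bears directly on the present change. With nothing in the series pointing to a shift, a step no larger than the scatter is expected, in either direction, leaving the number close to that of compound 1. Compound 4 is therefore estimated at 300 nM, with a range from 120 nM to 800 nM. The step of a 1.4-fold higher number from compound 1 to compound 4 (0.15 log units; within the scatter) is expected to be small.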

Compound 4, half-maximal inhibitory concentration: 260 nM
Compound 4: the middle estimate sits 1.2-fold (0.06 log units) above what was measured; the range from low to high includes it.
By their numbers in this assay, from the lowest: compounds 1, 4 and 2 (each within the scatter of the next); then compound 3.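

In this assay, 4-methylpiperidin-1-yl in place of 4-methylpiperazin-1-yl on a saturated chain carbon, three bonds along the chain from an oxygen on an aromatic ring, gives a 1.2-fold higher number from compound 1 to compound 4 (0.09 log units; within the scatter), so these data do not separate the two compounds. Unlike the earlier steps, which alter only the group on the aromatic nitrogen, this step concerns the chain and shows that, with the 2-fluorophenyl group held constant, a carbon can stand in place of the methyl-bearing ring nitrogen without a shift beyond the scatter. No supporting measurement is available to account for this result.

Still open, as far as these compounds go, is whether the same chain position would keep this level of activity with morpholin-4-yl, dimethylamino or a carboxylic acid in place of 4-methylpiperazin-1-yl, or with a longer chain carrying 4-methylpiperidin-1-yl. Also open, from the compounds shown here alone, is whether 4-methylpiperidin-1-yl would behave in the same way when paired with the 2-bromophenyl or 4-nitrophenyl group on the aromatic nitrogen.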